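The source may report more compounds than this note shows. Statements on the series, on what has been measured and on what is new or still open speak of the compounds shown alone.

In a functional assay on the whole organism for inhibition, with Rattus norvegicus as the target, read by paw edema, at a dose of 100 mg/kg by the oral route (a higher number here means more inhibition at the dose given (going by the name of the read-out), a lower number less inhibition), compound 2 `CN(C)CCNC(=O)c1c(O)c2cccnc2n(-c2ccccc2)c1=O` gives 22.6%. Among the measured compounds shown here, of the two numbers measured so far this is the larger one, yet the gap to compound 1 `CCCCNC(=O)c1c(O)c2cccnc2n(-c2ccccc2)c1=O`, which gives 12.8%, lies within the scatter, as the step of a number 9.8 percentage points higher from compound 1 to compound 2 (within the scatter) shows. Compound 3 `COc1ccc(NC(=O)c2c(O)c3cccnc3n(-c3ccccc3)c2=O)cc1` is not yet measured; it differs from compound 2 by 4-methoxyphenyl in place of 2-(dimethylamino)ethyl on an amide-type nitrogen. For the measured compounds named here, only that one measured step bears on this change, and it stayed within the scatter, so the expected step from compound 2 to compound 3 is a number 2.6 percentage points lower from compound 2 to compound 3 (within the scatter), nothing beyond the scatter. The estimate for compound 3 is 20%, within a range from 5% to 40%.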

Compound 3, a percentage reported as inhibition, in the whole organism at one dose (the size of the read-out at that dose, not a potency): 0.3%
The estimate for compound 3 lay 19.7 percentage points above the measured number, and the stated range ends above it.
By their numbers in this assay, from the lowest: compound 3; then compounds 1 and 2 (each within the scatter of the next).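

In this assay the two open chains had stayed within the scatter of each other, but a ring on the amide-type nitrogen gives a clear change: a number 22.3 percentage points lower from compound 2 to compound 3 (beyond the scatter) and a number 12.5 percentage points lower from compound 1 to compound 3 (beyond the scatter) both go beyond it. So at this position, 4-methoxyphenyl goes with less inhibition than either butyl or 2-(dimethylamino)ethyl. Nothing available explains this drop.

From the compounds shown here alone, whether the loss belongs to the aromatic ring or to its methoxy group stays open. A plain phenyl or a benzyl group on this nitrogen would help separate the two.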